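Swapping the carbamate arm of an adenosine-derived nucleoside

A few compounds are considered here, and "the series" means these few. Any claim that something is new, unique, unknown or untested is made for them only; others in the source may bear on it.

In an assay on DDT1 cells (Cricetulus griseus) for binding affinity to adenosine receptor A1 (Homo sapiens), read by radioligand binding (a higher number here means a weaker inhibitor, a lower number a stronger inhibitor), compound 1 `O=C(NC1CCC1)OC[C@H]1OC(n2cnc3c(NC4CCOC4)ncnc32)[C@H](O)[C@@H]1O` gives 306 nM, while compound 2 `O=C(NCc1ccccc1)OC[C@H]1OC(n2cnc3c(NC4CCOC4)ncnc32)[C@H](O)[C@@H]1O` gives 1830 nM, the higher of the two numbers seen so far; the change was a 6.0-fold higher number from compound 1 to compound 2 (0.78 log units; beyond the scatter). Compound 3 `C=CC/N=C(\S)OC[C@H]1OC(n2cnc3c(NC4CCOC4)ncnc32)[C@H](O)[C@@H]1O` carries a group of 6 heavy atoms (4 carbon, 1 nitrogen, 1 sulfur; no ring) in place of a group of 10 heavy atoms (8 carbon, 1 nitrogen, 1 oxygen; one six-membered aromatic ring of carbon only), on an oxygen on a saturated carbon. No measured step touches this exact change; the only step shown, from a smaller group without a ring to a larger one with a ring, raised the number, and compound 3 moves back toward a smaller group, so a modest drop is expected, a 2.3-fold lower number from compound 2 to compound 3 (0.36 log units; beyond the scatter), with wide uncertainty. Compound 3 is estimated at 800 nM, between 150 nM and 4000 nM.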

Compound 3, inhibition constant: 35 nM
Compound 3: the middle estimate sits 23-fold (1.36 log units) above what was measured; measured number outside the range, below it.
By their numbers in this assay, from the lowest: compound 3; then compound 1; then compound 2.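

At this position, on an oxygen on a saturated carbon, a ring is not needed for a low number in this assay: the ringless, sulfur-bearing group beats both the benzylcarbamoyl arm (a 52-fold lower number from compound 2 to compound 3 (1.72 log units; beyond the scatter)) and the cyclobutyl arm (an 8.7-fold lower number from compound 1 to compound 3 (0.94 log units; beyond the scatter)). Both steps change the size, the ring and the sulfur at once, so none can be singled out. Nothing here explains the drop. As far as these compounds go, whether the sulfur or the chain matters stays open. A matching oxygen group with the same chain, or a sulfur group carrying cyclobutyl, would help separate them.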